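Branched nitrogen substituents on the indole-type series

This account rests on a few compounds, and the source may have more. Where it says the series, first, only, none or still open, it means among the compounds named here.

Three compounds share one core and differ only in the group on the aromatic nitrogen. Compound 1 `CCCCCCn1ccc2cc(/C(C)=C/C(=O)Nc3ccccc3OCCCC(=O)O)ccc21` gives 77 nM in an assay on Prostate gland for inhibition of steroid 5-alpha-reductase (Rattus norvegicus); on this read-out lower numbers stand for stronger inhibition and higher numbers for weaker inhibition. Compound 2 `CCCCC(CCCC)n1ccc2cc(/C(C)=C/C(=O)Nc3ccccc3OCCCC(=O)O)ccc21` gives 21 nM in this assay, a step of a 3.7-fold lower number from compound 1 to compound 2 (0.56 log units; beyond the scatter). Compound 3 `C/C(=C\C(=O)Nc1ccccc1OCCCC(=O)O)c1ccc2c(ccn2C(C)c2ccccc2)c1` gives 19 nM in this assay, the lowest of the three numbers, with a 4.1-fold lower number from compound 1 to compound 3 (0.61 log units; beyond the scatter) but only a 1.1-fold lower number from compound 2 to compound 3 (0.04 log units; within the scatter). Compound 4 `CCCCC(c1ccccc1)n1ccc2cc(/C(C)=C/C(=O)Nc3ccccc3OCCCC(=O)O)ccc21` is not yet measured; it differs from compound 3 by propyl in place of hydrogen on a saturated chain carbon, two bonds along the chain from an aromatic carbon and an aromatic nitrogen. The two steps that bear on it, from hexyl to a branched chain and from hexyl to a phenyl-bearing carbon, were each modest and in the same direction, and compound 2 and compound 3 sit within the scatter of each other, so further lengthening is expected to give no step beyond the scatter, a 1.2-fold lower number from compound 3 to compound 4 (0.07 log units; within the scatter). Compound 4 is therefore estimated at 16 nM in this assay, between 6 nM and 45 nM.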

Compound 4, half-maximal inhibitory concentration: 9.8 nM
Beside the measured number, compound 4's estimate is 1.6-fold (0.21 log units) above it; the range from low to high includes it.
By their numbers in this assay, from the lowest: compounds 4, 3 and 2 (each within the scatter of the next, the first and the last beyond it); then compound 1.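

Going from 1-phenylethyl to 1-phenylpentyl stays within the scatter (a 1.9-fold lower number from compound 3 to compound 4 (0.29 log units; within the scatter)), so this position accepts propyl in place of hydrogen with no readable change in this assay. Phenyl in place of butyl does give a step beyond the scatter (a 2.1-fold lower number from compound 2 to compound 4 (0.33 log units; beyond the scatter)), which the pair of compound 2 and compound 3 did not show, and the whole change from hexyl reads (a 7.9-fold lower number from compound 1 to compound 4 (0.90 log units; beyond the scatter)). No evidence here explains these numbers.

Still open, from the compounds shown here alone, is whether a longer chain than butyl on this carbon holds the number, and whether cyclohexyl can replace phenyl.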